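This account rests on a few compounds, and the source may have more. Where it says the series, first, only, none or still open, it means among the compounds named here.

Measured compounds and their values in an assay on isolated protein for inhibition of serine/threonine-protein kinase PAK 1 (Homo sapiens), read by ADP-Glo, with a stated time of 40 min; a higher number here means a weaker inhibitor, a lower number a stronger inhibitor:
compound 1 `O=C(Nc1ccc(Br)cc1)NC1CCN(c2ncnc3[nH]ncc23)CC1`: 4030 nM
compound 2 `O=C(Nc1cccc(Cl)c1)NC1CCN(c2ncnc3[nH]ncc23)CC1`: 1240 nM
compound 3 `O=C(Nc1ccccc1Cl)NC1CCN(c2ncnc3[nH]ncc23)CC1`: 560 nM

Compound 3 gives the lowest number of the three; compound 2 is nearest, with a 2.2-fold lower number from compound 2 to compound 3 (0.35 log units; beyond the scatter), and compound 1 furthest, with a 7.2-fold lower number from compound 1 to compound 3 (0.86 log units; beyond the scatter). Compound 4 `O=C(Nc1ccc(Cl)c(Cl)c1)NC1CCN(c2ncnc3[nH]ncc23)CC1` is not yet measured in this assay. Its change from compound 3 is 3,4-dichlorophenyl in place of 2-chlorophenyl on an amide-type nitrogen. For the measured compounds named here, the steps that bear on it are a 3.3-fold lower number from compound 1 to compound 2 (0.51 log units; beyond the scatter), a 7.2-fold lower number from compound 1 to compound 3 (0.86 log units; beyond the scatter) and a 2.2-fold lower number from compound 2 to compound 3 (0.35 log units; beyond the scatter): the compounds carrying 4-bromophenyl and 3-chlorophenyl, compounds 1 and 2, gave the higher numbers, and no measured compound carries two chlorines. The number is therefore expected to rise, by about a 3.2-fold higher number from compound 3 to compound 4 (0.51 log units; beyond the scatter). Compound 4 is estimated at 1800 nM, within 600 nM to 5500 nM.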

Compound 4, half-maximal inhibitory concentration: 2290 nM
For compound 4 the middle estimate is 1.3-fold (0.10 log units) below the measured one; low and high end bracket the measured number.
By their numbers in this assay, from the lowest: compound 3; then compounds 2, 4 and 1 (each within the scatter of the next, the first and the last beyond it).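

For the compounds shown here, the 2-chlorophenyl group remains the one giving the lowest number at this place: the change to 3,4-dichlorophenyl brings a 4.1-fold higher number from compound 3 to compound 4 (0.61 log units; beyond the scatter) so two chlorines on the ring do not match it. Chloro in place of hydrogen on an aromatic carbon gives a 1.8-fold higher number from compound 2 to compound 4 (0.27 log units; within the scatter) and 3,4-dichlorophenyl in place of 4-bromophenyl gives a 1.8-fold lower number from compound 1 to compound 4 (0.25 log units; within the scatter) so neither step separates its two compounds. Nothing measured here explains these differences.

Still open, on these data alone, is whether a second chlorine added to the 2-chlorophenyl group of compound 3 would keep its low number. Also open, as far as these compounds go, is how a methoxy group or an amine on the phenyl ring would compare.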